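The source may report more compounds than this note shows. Statements on the series, on what has been measured and on what is new or still open speak of the compounds shown alone.

Measured compounds

- compound 1 `Cc1ccccc1OC1CCN(CCC2CCCc3ccccc3C2=O)CC1`: 11.2 nM
- compound 2 `O=C1c2ccccc2CCCN1CCN1CCC(Oc2ccccc2)CC1`: 20.4 nM

In an assay on isolated protein for binding affinity to 5-hydroxytryptamine receptor 7 (Homo sapiens) (on this read-out higher numbers stand for weaker inhibition and lower numbers for stronger inhibition), compound 1 gives 11.2 nM. In this assay compound 2 gives 20.4 nM, the higher of the two numbers shown; its nearest neighbour is compound 1, and the gap between them is within the scatter, so the two values are read as equivalent. Going by the values given here, no step between measured compounds is available for this pair, so only the two values themselves are noted.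

Compound 3 `O=C(c1ccc(F)cc1)C1CCN(CCN2CCCc3ccccc3C2=O)CC1` is not yet measured in this assay. Relative to compound 2 the change is (4-fluorophenyl)carbonyl in place of phenoxy on a saturated ring carbon. The core of compound 2 is kept. Among the compounds with values here, nothing among the measured compounds carries the entering group, so the direction of the step rests on no measured precedent.

The expectation is a modest move toward a higher number, possibly within the scatter, so that from compound 2 the step of a 1.6-fold higher number from compound 2 to compound 3 (0.20 log units; within the scatter) is estimated. For compound 3 the expected value in this assay is 32 nM, with a range from 8 nM to 130 nM.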

Compound 3, inhibition constant: 1.66 nM
Compound 3: middle estimate off by 19-fold (1.29 log units), on the high side; measured number outside the range, below it.
By their numbers in this assay, from the lowest: compound 3; then compounds 1 and 2 (each within the scatter of the next).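

In this assay, going by these compounds alone, (4-fluorophenyl)carbonyl in place of phenoxy on a saturated ring carbon, three ring bonds from the ring nitrogen, gives a 12-fold lower number from compound 2 to compound 3 (1.09 log units; beyond the scatter) and provides the first step beyond the scatter. Within the data shown here, the earlier values offered no step at all, whereas this one shows that the read-out is sensitive to the group at this position while the rest of the structure stays the same. By the counts, the entering group has more heavy atoms than the leaving one and adds a fluorine and a double bond outside aromatic rings, while the six-membered aromatic ring of carbon, the single hydrogen-bond acceptor and the absence of net charge stay the same. No available measurement accounts for the size of this step.

The compounds shown do not separate the contributions of the fluorine and the carbonyl, a question that an unsubstituted benzoyl group and a 4-fluorophenoxy group at the same carbon would address. Also open, as far as these compounds go, is whether the gain survives when an amine replaces the carbonyl link to the aromatic ring, or when a longer chain joins the two halves of the molecule.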